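A few compounds are considered here, and "the series" means these few. Any claim that something is new, unique, unknown or untested is made for them only; others in the source may bear on it.

Compounds measured so far:
- compound 1, `CCCNC(=O)/N=C(\N)Nc1cccc(-c2csc(N)n2)c1`: "not determined" (no result reported)
- compound 2, `Cc1nc(N)sc1CCCN/C(N)=N/C(=S)N[C@H](C)c1ccccc1`: 0.11
- compound 3, `Cc1nc(N)sc1CCCN/C(N)=N/C(=O)NCc1ccccc1`: 0.33

The three compounds share a core in which a guanidine-like unit links an aminothiazole-bearing chain to an acylated or thioacylated nitrogen. Going by the values given here, in a functional assay on HEK293T cells for agonist activity at histamine H2 receptor (Homo sapiens), read by beta-arrestin recruitment (on this read-out higher numbers stand for larger maximal responses and lower numbers for smaller maximal responses), compound 1 was left without a number, so only two values can be compared. Among those two, compound 3 stands highest, and its gap to compound 2 lies beyond the usual scatter of the measurement.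

Compound 4, `Cc1nc(N)sc1CCCN/C(N)=N/C(=O)NC(C)c1ccco1`, differs from compound 3 in one place: 1-(furan-2-yl)ethyl in place of benzyl on an amide-type nitrogen. Among the compounds with values here, no step between measured compounds covers this kind of change, so its size cannot be read from the data at hand. The unmeasured compound 4 is expected to stay near the value of compound 3, with the step a number 0.030 lower from compound 3 to compound 4 (within the scatter) estimated as small and, if anything, slightly downward, not clearly beyond the scatter. For compound 4 the estimate in this assay is 0.3, with a likely range from 0.15 to 0.5.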

Compound 4, intrinsic activity: the largest response reached, as a fraction of the reference agonist's: 0.25
Compound 4: the middle estimate sits 0.050 above what was measured, and the stated range covers the measured number.
By their numbers in this assay, from the lowest: compound 2; then compounds 4 and 3 (each within the scatter of the next).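

In this assay, going by these compounds alone, the step is a number 0.080 lower from compound 3 to compound 4 (within the scatter), the first change at this amide-type nitrogen that can be read on its own. At this place, then, one six-membered aromatic ring of carbon only gave way to a five-membered aromatic ring with one hetero atom, with the same count of heavy atoms and one more hydrogen-bond acceptor, and the read-out stayed within the scatter. Nothing at hand accounts for this tolerance.

The ring and the ethyl linkage differ together in this pair, so the compounds shown cannot tell what each contributes alone; furan-2-ylmethyl or 1-phenylethyl on the same nitrogen would separate them. They also leave open how this place would respond to a group of another kind, such as a carboxylic acid or an amine on the ring.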